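The source may report more compounds than this note shows. Statements on the series, on what has been measured and on what is new or still open speak of the compounds shown alone.

Measured so far:
- compound 1, `CCCSc1nc(N/N=C/c2c[nH]c3ccccc23)c2nnn(Cc3ccccc3)c2n1`, which in a functional assay on ECa-109 cells (Homo sapiens) for antiproliferative activity, read by MTT assay, with a stated time of 72 h (a higher number here means a weaker inhibitor, a lower number a stronger inhibitor), gives 8690 nM.
- compound 2, `CCCSc1nc(N/N=C/c2ccccc2F)c2nnn(Cc3ccccc3)c2n1`, for which this assay reports only a limit of the assay, > 64000 nM.

Compound 2 thus stands at the weak end of what has been measured: its reading is a limit rather than a number, and the step of an at least 7.3-fold higher number from compound 1 to compound 2 (0.86 log units; beyond the scatter) shows how far it sits from compound 1. Compound 3, `CCCSc1nc(N/N=C/c2ccc3ccccc3c2)c2nnn(Cc3ccccc3)c2n1`, is not yet measured. It differs from compound 2 by naphthalen-2-yl in place of 2-fluorophenyl on a carbon with a double bond to nitrogen. Among the compounds with values here, the one measured step that bears on this change is an at least 7.3-fold higher number from compound 1 to compound 2 (0.86 log units; beyond the scatter), in which 1H-indol-3-yl was replaced by 2-fluorophenyl and inhibition weakened beyond the scatter. Returning to a larger aromatic group, naphthalen-2-yl, is expected to move the number in this assay down again, by an at least 4.2-fold lower number from compound 2 to compound 3 (0.63 log units; beyond the scatter), although naphthalen-2-yl is not 1H-indol-3-yl. Compound 3 is therefore estimated at 15000 nM, between 4000 nM and 64000 nM.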

Compound 3, half-maximal inhibitory concentration: > 64000 nM
Compound 3: only a limit was reported; the forecaster's own chance of this, stated with the estimate: 30%; at least 4.2-fold (0.63 log units) between middle value and limit.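

Compound 3 shows that a larger aromatic group of carbon only, placed on a carbon with a double bond to nitrogen, does not on its own restore what compound 1 shows. In this assay, the change to naphthalen-2-yl gives an at least 7.3-fold higher number from compound 1 to compound 3 (0.86 log units; beyond the scatter), the same lower bound on the loss as with 2-fluorophenyl. The step between compound 2 and compound 3 cannot be read, because both readings are limits of the assay, not numbers: the limit of > 64000 nM in this assay, at which 2 of the 3 values shown sit.

Of the three groups shown, only 1H-indol-3-yl gives a measured number, and these compounds cannot tell which of its features matters. As far as these compounds go, it also remains open whether a phenyl ring carrying an amine or a hydroxyl group would give a measured number at this place.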